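The source may report more compounds than this note shows. Statements on the series, on what has been measured and on what is new or still open speak of the compounds shown alone.

Measured compounds:
compound 1, `Cc1cc(-c2ccco2)nc(Nc2ccc(N(C)C)cc2)n1`, which in a functional assay for inhibition, with Homo sapiens as the target (on this read-out lower numbers stand for stronger inhibition and higher numbers for weaker inhibition), gives 5900 nM
compound 2, `CN(C)c1ccc(Nc2nccc(-c3ccco3)n2)cc1`, which in this assay gives 1900 nM
compound 3, `c1ccc(Nc2nccc(-c3c[nH]c4ccccc34)n2)cc1`, which in this assay gives 3000 nM

Compound 1 and compound 2 share one core and differ only by methyl in place of hydrogen on an aromatic carbon, a step of a 3.1-fold higher number from compound 2 to compound 1 (0.49 log units; beyond the scatter). Compound 3 has another core; the difference between the two cores is not broken down here. Its value and those of compound 1 and compound 2 lie within the scatter of one another.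

Compound 4, `Cc1cccc(Nc2nccc(-c3c[nH]c4ccccc34)n2)c1`, carries methyl in place of hydrogen on an aromatic carbon on the core of compound 3. This is the same kind of change as from compound 2 to compound 1, not the same: there the methyl enters on a six-membered aromatic ring with 2 nitrogen, next to the ring nitrogen, meta to a furan-2-yl group and opposite the ring nitrogen, whereas in compound 4 it enters on a six-membered aromatic ring of carbon only, meta to a large group.

For compound 4 a step of a 1.5-fold higher number from compound 3 to compound 4 (0.18 log units; within the scatter) is expected, smaller than the earlier one, because a 3.1-fold higher number from compound 2 to compound 1 (0.49 log units; beyond the scatter) was seen on another ring and rests on a single pair. Compound 4 is therefore estimated at 4500 nM, between 1800 nM and 11000 nM.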

Compound 4, half-maximal inhibitory concentration: 2200 nM
Estimate against measurement, compound 4: 2.0-fold (0.31 log units) above, and the stated range covers the measured number.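

In this assay, methyl in place of hydrogen on an aromatic carbon gives a 1.4-fold lower number from compound 3 to compound 4 (0.13 log units; within the scatter), a step that lies within the scatter, so on the core of compound 3 this change has no clear effect on the read-out. Set beside the earlier step, the same change does not carry over in size from one core to the other: the same change on two cores in this assay, a 3.1-fold higher number (0.49 log units; beyond the scatter) from compound 2 to compound 1 and a 1.4-fold lower number (0.13 log units; within the scatter) from compound 3 to compound 4, 4.2-fold (0.63 log units) apart, beyond the scatter of two such steps The comparison does not show whether this gap belongs to the core or to the ring that takes the methyl, which differs between the two pairs, and with a single pair on each core it gives no rule for a further core.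

The compounds shown leave open how a carboxylic acid or a longer chain such as propyl would read in this assay in the place of the methyl of compound 4. They also leave open whether a methyl on the same ring would give the same step on the core of compound 2 and on the core of compound 3.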